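This account rests on a few compounds, and the source may have more. Where it says the series, first, only, none or still open, it means among the compounds named here.

Three pyrazole-type compounds built on the same shared core have been tested. Compound 1 `O=[N+]([O-])c1ccc(-c2cc(-c3ccc(F)cc3)n[nH]2)cc1` gives 18300 nM in a functional assay on AGS cells (Homo sapiens) for inhibition, read by MTT assay, with a stated time of 48 h; a higher number here means a weaker inhibitor of growth, a lower number a stronger inhibitor of growth. Compound 2 `COc1ccc(-c2cc(-c3ccccc3)n[nH]2)cc1` gives 11300 nM in this assay, and compound 3 `COc1ccc(-c2cc(-c3ccc(C(F)(F)F)cc3)n[nH]2)cc1` gives 14800 nM in the same assay. The one direct comparison among these, a 1.3-fold higher number from compound 2 to compound 3 (0.12 log units; within the scatter), shows that putting trifluoromethyl on the aromatic carbon changed little. Compound 3 thus sits within the scatter of both compound 1 and compound 2, so none of the three can be told apart on these numbers.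

Compound 4 `Oc1ccc(-c2cc(-c3ccc(C(F)(F)F)cc3)n[nH]2)cc1` differs from compound 3 by hydrogen in place of methyl on an oxygen on an aromatic ring. Among the compounds with values here, no measured step addresses this change; the only step available, a 1.3-fold higher number from compound 2 to compound 3 (0.12 log units; within the scatter), concerns a different position and was small. With nothing in the data pointing either way, no step beyond the scatter is expected in this assay. Compound 4 is therefore expected to give about 14000 nM, with a likely range from 5000 nM to 40000 nM. The estimated step of a 1.1-fold lower number from compound 3 to compound 4 (0.02 log units; within the scatter) is expected to remain within the scatter.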

Compound 4, concentration for 50% growth inhibition: 9800 nM
Compound 4: the middle estimate sits 1.4-fold (0.15 log units) above what was measured; the measured number falls inside the stated range.
By their numbers in this assay, from the lowest: compounds 4, 2, 3 and 1 (each within the scatter of the next).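

Methoxy to hydroxy is the first change seen at this position, and it gives a 1.5-fold lower number from compound 3 to compound 4 (0.18 log units; within the scatter) in this assay. The methyl on this oxygen can therefore be removed without any measurable loss of growth inhibition, whereas the earlier step showed only that trifluoromethyl in place of hydrogen at a different place changed little. No other measurement is available to explain this result.

Going by these compounds, it remains open whether a longer chain on this oxygen, such as ethyl, or an amine or a carboxylic acid in place of the hydroxy group, would move the number beyond the scatter. With each of the four compounds within the scatter of the next, no structural change shown here has yet been tied to a real difference in growth inhibition.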